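Swapping an Iodine for a Dichlorophenyl Group

A few compounds are considered here, and "the series" means these few. Any claim that something is new, unique, unknown or untested is made for them only; others in the source may bear on it.

Compound 1 `O=C(Nc1ccc(I)cc1F)c1ccccc1O` is the reference point in an ADME assay on RAW264.7 cells (Mus musculus) for cytotoxicity, read by MTT assay, with a stated time of 24 h (a lower number here means that less compound is tolerated, a higher number that more compound is tolerated), where compound 1 gives 23300 nM. Two close relatives have been measured in the same way. Compound 2 `COc1ccccc1C(=O)Nc1ccc(I)cc1F` is the methyl ether of compound 1, and in this assay compound 2 reaches only a limit of > 40000 nM. Compound 3 `COc1ccc(C(=O)Nc2ccc(I)cc2F)c(O)c1` carries a methoxy in place of hydrogen on an aromatic carbon; in this assay compound 3 gives 27600 nM. Among the two plain numbers compound 1 is the lowest, with compound 3 nearest, and the step is a 1.2-fold higher number from compound 1 to compound 3 (0.07 log units; within the scatter). The other step is an at least 1.7-fold higher number from compound 1 to compound 2 (0.23 log units; that floor lies within the scatter); a limit is involved here, as the limit of > 40000 nM in this assay, at which 1 of the 3 values shown sits.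

Compound 4 `O=C(Nc1ccc(-c2ccc(Cl)cc2Cl)cc1F)c1ccccc1O` changes a different part of the molecule: 2,4-dichlorophenyl in place of iodo on an aromatic carbon. Neither measured step touches the iodo group, so they offer little guidance. The expectation for compound 4 is therefore a step within the scatter, a 1.2-fold lower number from compound 1 to compound 4 (0.07 log units; within the scatter). The estimate for compound 4 is 20000 nM, within the range 7000 nM to 50000 nM.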

Compound 4, half-maximal cytotoxic concentration: 29800 nM
The estimate for compound 4 lay 1.5-fold (0.17 log units) below the measured number; the range from low to high includes it.
By their numbers in this assay, from the lowest: compounds 1, 3 and 4 (each within the scatter of the next). At a limit, above all of these: compound 2.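

For the compounds shown here, the earlier steps all left the iodo group in place, so this is the first reading at the aromatic carbon meta to the fluoro group. In this assay, putting 2,4-dichlorophenyl, with 8 heavy atoms and an aromatic ring of its own, in place of iodo, with 1 heavy atom, gives a 1.3-fold higher number from compound 1 to compound 4 (0.11 log units; within the scatter). For this pair, then, a much larger group and iodo cannot be told apart, and nothing shown bears on why that is so.

On these data alone, whether this position is as undemanding for other kinds of group stays open, since an amine, a carboxylic acid or a longer chain there could give quite a different number. As far as these compounds go, it is also open whether plain phenyl, without the two chlorines, would match compound 4.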